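The source may report more compounds than this note shows. Statements on the series, on what has been measured and on what is new or still open speak of the compounds shown alone.

In an ADME assay on MRC5 cells (Homo sapiens) for inhibition, with a stated time of 72 h (a higher number here means that more compound is needed for the effect, a lower number that less compound is needed), compound 1 `CO[C@H]1CC[C@H](NC(=O)c2n[nH]cc2NC(=O)c2cnc3ccccn23)CC1` gives 5900 nM, compound 3 `CO[C@H]1CC[C@H](NC(=O)c2n[nH]cc2NC(=O)c2ccc(F)cc2F)CC1` gives 11000 nM, and compound 2 `COc1cccc(OC)c1C(=O)Nc1c[nH]nc1C(=O)N[C@H]1CC[C@H](O)CC1` gives 34000 nM, the highest of the three numbers. Within the data shown here, the only step measured here, a 1.9-fold higher number from compound 1 to compound 3 (0.27 log units; within the scatter), exchanges one acyl group for another on the shared core and leaves the part that changes next untouched. Compound 4 `COc1cccc(OC)c1C(=O)Nc1c[nH]nc1C(=O)Nc1ccccc1` differs from compound 2 by phenyl in place of 4-hydroxycyclohexyl on an amide-type nitrogen. Among the measured compounds shown here, no measured pair shows this kind of exchange on the amide-type nitrogen, so nothing here points to a step in either direction, and the expectation stays close to compound 2 with a wide margin. Compound 4 is estimated at 25000 nM, with a range from 8000 nM to 80000 nM, which would mean a 1.4-fold lower number from compound 2 to compound 4 (0.13 log units; within the scatter).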

Compound 4, half-maximal effective concentration: > 50000 nM
Compound 4: a limit, no number; the forecaster's own chance of this, stated with the estimate: 20%; middle value at least 2.0-fold (0.30 log units) away from the limit.
By their numbers in this assay, from the lowest: compounds 1 and 3 (each within the scatter of the next); then compound 2. At a limit, above all of these: compound 4.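

Compound 4 carries only a limit of the assay, not a number: the limit of > 50000 nM in this assay, at which 1 of the 4 values shown sits.

Among these compounds, this is the first view of the amide-type nitrogen, which the earlier step left untouched. The exchange there gives an at least 1.4-fold higher number from compound 2 to compound 4 (0.16 log units; that floor lies within the scatter), so phenyl in place of 4-hydroxycyclohexyl does not bring the number down, although the true size of the step cannot be told.

As far as these compounds go, it remains open how a 4-aminocyclohexyl group or a short chain such as ethyl would read on this nitrogen. Also open, from the compounds shown here alone, is whether phenyl would behave the same way with the acyl groups of compound 1 and compound 3.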